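The source may report more compounds than this note shows. Statements on the series, on what has been measured and on what is new or still open speak of the compounds shown alone.

Measured in an ADME assay on NHDF cells (Homo sapiens) for cytotoxicity, read by MTT assay, with a stated time of 72 h; on this read-out higher numbers stand for weaker inhibition and lower numbers for stronger inhibition:
- Compound 1 `COc1cccc(/C=C2\CCC/C(=C\c3cccc(Cl)c3)C2=O)c1OC`: 21400 nM
- Compound 2 `COc1cccc(/C=C2\CCC/C(=C\c3ccccc3Br)C2=O)c1OC`: > 50000 nM

Compound 2 reads > 50000 nM, which is a limit of the assay and not a number. Compound 3 `COc1cccc(/C=C2\CCC/C(=C\c3cccc(Br)c3)C2=O)c1OC` is not yet measured. It carries 3-bromophenyl in place of 2-bromophenyl on a double-bonded chain carbon bound to a double-bonded ring carbon. Going by the values given here, the one measured step bearing on this is an at least 2.3-fold higher number from compound 1 to compound 2 (0.36 log units; beyond the scatter), which put 2-bromophenyl in place of 3-chlorophenyl. A step of similar modest size towards a lower number is therefore expected in this assay, namely an at least 2.0-fold lower number from compound 2 to compound 3 (0.31 log units; beyond the scatter). For compound 3 the estimated value is 24000 nM, with an expected range of 11000 nM to 50000 nM.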

Compound 3, half-maximal inhibitory concentration: 23900 nM
Estimate against measurement, compound 3: 1.0-fold (0.00 log units) above; the range from low to high includes it.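

In this assay, 3-bromophenyl in place of 2-bromophenyl, with the same atoms joined differently, gives an at least 2.0-fold lower number from compound 2 to compound 3 (0.32 log units; beyond the scatter). The reading of compound 2 is a limit of the assay and not a number: the limit of > 50000 nM in this assay, at which 1 of the 3 values shown sits. Bromo in place of chloro on an aromatic carbon gives a 1.1-fold higher number from compound 1 to compound 3 (0.05 log units; within the scatter), so among these compounds the reading follows where the halogen sits on the ring and not which halogen it is. As far as these compounds go, whether an amine or a carboxylic acid at that ring place would read like the halogens remains open.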